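Isopentyl in place of propyl on the ether chain

The compounds below may be only part of what the source reports. "The series", "measured", "known", "first", "only" and "open" are said of these compounds alone.

Compound 1 `[O-][n+]1nc(NCOC2CCCCC2)[n+]([O-])c2ccccc21`: 6670 nM
Compound 2 `[O-][n+]1nc(NCOCc2ccccc2)[n+]([O-])c2ccccc21`: 11900 nM
Compound 3 `CCCOCNc1n[n+]([O-])c2ccccc2[n+]1[O-]`: 7400 nM

All three were measured in a functional assay on PC-3 cells (Homo sapiens) for cytotoxicity, read by MTT assay, with a stated time of 72 h; a lower number here means a stronger inhibitor, a higher number a weaker inhibitor. Compound 3 lies within the scatter of both companions: a 1.1-fold higher number from compound 1 to compound 3 (0.05 log units; within the scatter), and a 1.6-fold lower number from compound 2 to compound 3 (0.21 log units; within the scatter), while a 1.8-fold higher number from compound 1 to compound 2 (0.25 log units; within the scatter). Compound 4 `CC(C)CCOCNc1n[n+]([O-])c2ccccc2[n+]1[O-]` differs from compound 3 by isopropyl in place of methyl on a saturated chain carbon, two bonds along the chain from an oxygen on a saturated carbon. For the measured compounds named here, the steps that bear on this change are the three exchanges of the group on that oxygen, cyclohexyl, benzyl and propyl, none of which left the scatter, so in this assay no step beyond the scatter is expected for compound 4 either. Compound 4 is therefore estimated at 7000 nM, with a range from 3000 nM to 17000 nM. That estimate means an expected step of a 1.1-fold lower number from compound 3 to compound 4 (0.02 log units; within the scatter), inside the scatter.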

Compound 4, half-maximal inhibitory concentration: 7520 nM
Compound 4: the middle estimate sits 1.1-fold (0.03 log units) below what was measured; the measured number falls inside the stated range.
By their numbers in this assay, from the lowest: compounds 1, 3, 4 and 2 (each within the scatter of the next).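

Isopropyl in place of methyl, on a saturated chain carbon two bonds along the chain from an oxygen on a saturated carbon, stays within the scatter in this assay, with a 1.0-fold higher number from compound 3 to compound 4 (0.01 log units; within the scatter). The isopentyl group also stays within the scatter against the two ring-bearing groups, with a 1.6-fold lower number from compound 2 to compound 4 (0.20 log units; within the scatter) and a 1.1-fold higher number from compound 1 to compound 4 (0.05 log units; within the scatter), so a branched chain joins the straight chain and both ring-bearing groups on this oxygen without any step beyond the scatter. No measurement shown accounts for this flat result. Still open, from the compounds shown here alone, is whether an amine or a carboxylic acid at the end of the ether chain, or a much longer chain, would leave the scatter.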